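Putting a Chain Back on Compound 3

A few compounds are considered here, and "the series" means these few. Any claim that something is new, unique, unknown or untested is made for them only; others in the source may bear on it.

Three compounds share one core and differ only in what sits on the triple-bonded carbon. Compound 1 `CCCCCCC#Cc1ccc(S(=O)(=O)Nc2cccc(-c3csc(NC(C)=O)n3)c2)cc1` gives 12.8% in a functional assay on A-375 cells (Homo sapiens) for antiproliferative activity, read by trypan blue exclusion, with a stated time of 48 h, tested at 5 uM; on this read-out lower numbers stand for a stronger effect and higher numbers for a weaker effect at the one concentration tested. Compound 2 `CCCCC#Cc1ccc(S(=O)(=O)Nc2cccc(-c3csc(NC(C)=O)n3)c2)cc1` gives 9.3% in this assay, and the step of a number 3.5 percentage points lower from compound 1 to compound 2 (within the scatter) lies within the scatter. Compound 3 `C#Cc1ccc(S(=O)(=O)Nc2cccc(-c3csc(NC(C)=O)n3)c2)cc1` gives 38.3% in this assay, the highest of the three numbers and hence the weakest effect shown. The two steps that lead to it, a number 25.5 percentage points higher from compound 1 to compound 3 (beyond the scatter) and a number 29 percentage points higher from compound 2 to compound 3 (beyond the scatter), both raise the number beyond the scatter, so removing the chain from the triple-bonded carbon weakens the effect among these compounds.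

Compound 4 `CC(=O)Nc1nc(-c2cccc(NS(=O)(=O)c3ccc(C#CCCc4ccccc4)cc3)c2)cs1` goes the other way: phenethyl in place of hydrogen on a triple-bonded carbon. The steps from compound 1 and compound 2 to compound 3 are the ones that bear on this change, and both were modest. Restoring a chain on that carbon is therefore expected to lower the number by a similar amount, a step of a number 25.3 percentage points lower from compound 3 to compound 4 (beyond the scatter). Compound 4 is estimated at 13%, within 4% to 30%.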

Compound 4, a percentage reported as activity, at one concentration (the size of the read-out at that concentration, not a potency): 4.2%
Compound 4: middle estimate off by 8.8 percentage points, on the high side, and the stated range covers the measured number.
By their numbers in this assay, from the lowest: compounds 4, 2 and 1 (each within the scatter of the next); then compound 3.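

In this assay, among the compounds shown here, phenethyl in place of hydrogen on a triple-bonded carbon gives a number 34.1 percentage points lower from compound 3 to compound 4 (beyond the scatter) and so shows that this position also tolerates a chain ending in a six-membered aromatic ring, where the earlier compounds carried only plain alkyl chains. The steps of a number 5.1 percentage points lower from compound 2 to compound 4 (within the scatter) and a number 8.6 percentage points lower from compound 1 to compound 4 (within the scatter) show that phenyl at the chain's end cannot be told apart from the ethyl or butyl it replaces. Among these four compounds, then, the clear divide lies between having a chain on this carbon and having none, and the three chains shown cannot be ranked.

Going by these compounds, whether a shorter chain such as propyl, or a chain ending in an amine or a carboxylic acid, would keep the effect remains open. No evidence here explains why a chain on this carbon matters.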